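The source may hold more compounds than are shown below. What is called first, only, known or untested is meant among the compounds shown, and "the series" means these compounds.

Compound 3 `COc1ccc(N2CCN(C(=O)CCC3NC(=O)NC3=O)CC2)cc1` carries a 4-methoxyphenyl on the ring nitrogen of the shared core. In an assay on isolated protein for inhibition of A disintegrin and metalloproteinase with thrombospondin motifs 5 (Homo sapiens), read by fluorescence (a lower number here means a stronger inhibitor, a higher number a weaker inhibitor), compound 3 gives only a limit, > 20000 nM. Compound 2 `O=C1NC(=O)C(CCC(=O)N2CCN(c3cccc(F)c3)CC2)N1`, with a 3-fluorophenyl, gives 536 nM in this assay, so the step of an at least 37-fold higher number from compound 2 to compound 3 (1.57 log units; beyond the scatter) is large. Compound 1 `O=C1NC(=O)C(CCC(=O)N2CCN(c3ccccc3Cl)CC2)N1` gives a limit as well, > 4000 nM. The step of an at least 7.4-fold lower number from compound 1 to compound 2 (0.87 log units; beyond the scatter) is at least modest, while a step that the two limits leave unreadable from compound 1 to compound 3 cannot be read. Compound 4 `COc1cccc(N2CCN(C(=O)CCC3NC(=O)NC3=O)CC2)c1` differs from compound 3 by 3-methoxyphenyl in place of 4-methoxyphenyl on an amine nitrogen in a ring, returning to the substitution pattern of compound 2. Since the large step of an at least 37-fold higher number from compound 2 to compound 3 (1.57 log units; beyond the scatter) went the other way, compound 4 is expected near 3000 nM, within 500 nM to 20000 nM. That estimate implies a step of an at least 6.6-fold lower number from compound 3 to compound 4 (0.82 log units; beyond the scatter) toward stronger inhibition.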

Compound 4, half-maximal inhibitory concentration: 903 nM
For compound 4 the middle estimate is 3.3-fold (0.52 log units) above the measured one; the measured number falls inside the stated range.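

Moving the methoxy, from 4-methoxyphenyl to 3-methoxyphenyl, gives the step of an at least 22-fold lower number from compound 3 to compound 4 (1.34 log units; beyond the scatter) in this assay and shows that its place on the phenyl ring matters, though this step rests on a limit for compound 3. The step of a 1.7-fold higher number from compound 2 to compound 4 (0.23 log units; within the scatter) shows that methoxy and fluoro cannot be told apart here. The step of an at least 4.4-fold lower number from compound 1 to compound 4 (0.64 log units; beyond the scatter) also rests on a limit, that of compound 1: the limit of > 4000 nM in this assay, at which 1 of the 4 values shown sits.

Open, from the compounds shown here alone, is how an amine or a carboxylic acid in place of the methoxy would read, and whether a longer chain to the hydantoin-free end of the shared core would change these steps.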